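Para-aryl variation on the imidazole series, agonism at bombesin receptor subtype-3

This account rests on a few compounds, and the source may have more. Where it says the series, first, only, none or still open, it means among the compounds named here.

Measured so far:
compound 1, `CCC(C)(C)Cc1c[nH]c(CCc2ccc(-n3ncnn3)cc2)n1`: 99 nM
compound 2, `CCC(C)(C)Cc1c[nH]c(CCc2ccc(N3CCCCC3)cc2)n1`: 133 nM
compound 3, `CCC(C)(C)Cc1c[nH]c(CCc2ccc(-n3ccnn3)cc2)n1`: 111 nM

All three values come from a functional assay on HEK293 cells for agonist activity at Bombesin receptor subtype-3 (Mus musculus), read by luminescence and calcium flux, with a stated time of 10 min; a higher number here means that more compound is needed for the effect, a lower number that less compound is needed. Compound 3 sits within the scatter of both neighbours: a 1.1-fold higher number from compound 1 to compound 3 (0.05 log units; within the scatter), and a 1.2-fold lower number from compound 2 to compound 3 (0.08 log units; within the scatter). The same holds for the remaining pair, a 1.3-fold higher number from compound 1 to compound 2 (0.13 log units; within the scatter).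

Compound 4, `CCC(C)(C)Cc1c[nH]c(CCc2ccc(-c3ccccc3C(=O)O)cc2)n1`, is not yet measured. It differs from compound 3 by 2-carboxyphenyl in place of 1H-1,2,3-triazol-1-yl on an aromatic carbon. Going by the values given here, every measured step so far swaps a group at this same place, and none of them moved beyond the scatter; the only step that brings in a six-membered ring of carbon only is a 1.3-fold higher number from compound 1 to compound 2 (0.13 log units; within the scatter), which also stayed flat. Among the compounds with values here, no measured step puts a carboxylic acid at this place, so the range must be wider. For compound 4 the expectation is a 1.4-fold higher number from compound 3 to compound 4 (0.13 log units; within the scatter), giving an estimated value of 150 nM, within 40 nM to 600 nM.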

Compound 4, half-maximal effective concentration: 94 nM
Beside the measured number, compound 4's estimate is 1.6-fold (0.20 log units) above it, and the stated range covers the measured number.
By their numbers in this assay, from the lowest: compounds 4, 1, 3 and 2 (each within the scatter of the next).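

In this assay the 2-carboxyphenyl group, the only carboxylic acid in the set, stays within the scatter of all three earlier groups: a 1.2-fold lower number from compound 3 to compound 4 (0.07 log units; within the scatter), a 1.4-fold lower number from compound 2 to compound 4 (0.15 log units; within the scatter) and a 1.1-fold lower number from compound 1 to compound 4 (0.02 log units; within the scatter). The flat picture on this aromatic carbon now takes in a carboxylic acid carried on a six-membered aromatic ring of carbon only. Nothing available explains this flatness.

Open, going by these compounds, is whether an amine or a longer chain at this place would also stay within the scatter. On these data alone, whether the flatness survives a change to the shared core is also open.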